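Swapping the Hydrazone Arm of a Weak Inhibitor

This account rests on a few compounds, and the source may have more. Where it says the series, first, only, none or still open, it means among the compounds named here.

Compound 2 `CCCSc1nc(N/N=C/c2ccc(Cl)cc2)c2nnn(Cc3ccccc3)c2n1` is one of three hydrazones built on a shared core and tested in a functional assay on ECa-109 cells (Homo sapiens) for antiproliferative activity, read by MTT assay, with a stated time of 72 h; a higher number here means a weaker inhibitor, a lower number a stronger inhibitor. In this assay compound 2 gives > 64000 nM, which is a limit of the assay rather than a number. Compound 1 `CCCSc1nc(N/N=C/c2ccc(C)cc2)c2nnn(Cc3ccccc3)c2n1` differs from compound 2 only by a chloro in place of methyl on an aromatic carbon. In this assay compound 1 gives > 64000 nM, again a limit. The step that the two limits leave unreadable from compound 1 to compound 2 is therefore unreadable. Compound 3 `C#CCSc1nc(N/N=C/c2cc(OC)c(OC)c(OC)c2)c2nnn(Cc3ccccc3)c2n1` differs in more than one place, and in this assay compound 3 gives 6540 nM. Among the measured compounds shown here, with the limit of > 64000 nM in this assay, at which 2 of the 3 values shown sit, and only one number, no measured step shows how a change on the aromatic ring moves the value.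

Compound 4 `CCCSc1nc(N/N=C(\C)c2ccccc2O)c2nnn(Cc3ccccc3)c2n1` is not yet measured. It differs from compound 2 by a group of 10 heavy atoms (8 carbon, 1 nitrogen, 1 oxygen; one six-membered aromatic ring of carbon only) in place of a group of 9 heavy atoms (7 carbon, 1 nitrogen, 1 chlorine; one six-membered aromatic ring of carbon only), on a nitrogen on an aromatic ring. For the measured compounds named here, no measured step bears on this change, so neither size nor direction of the step in this assay can be read from the data, and compound 4 may stay at the limit or yield a number. Compound 4 is therefore expected to give roughly 40000 nM, within a wide range from 8000 nM to 200000 nM. That estimate would mean an expected step of an at least 1.6-fold lower number from compound 2 to compound 4 (0.20 log units; that floor lies within the scatter), itself uncertain.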

Compound 4, half-maximal inhibitory concentration: 11100 nM
Estimate against measurement, compound 4: 3.6-fold (0.56 log units) above; the range from low to high includes it.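

In this assay the arm on a nitrogen on an aromatic ring now gives readable steps: an at least 5.7-fold lower number from compound 2 to compound 4 (0.76 log units; beyond the scatter) and an at least 5.7-fold lower number from compound 1 to compound 4 (0.76 log units; beyond the scatter). In both steps the group of compound 4 is the one that enters. This shows that a change at this position can move the value beyond the scatter, which the methyl and chloro arms alone could not show. Each step is only a floor, because its starting point is a limit and not a number: the limit of > 64000 nM in this assay, at which 2 of the 4 values shown sit.

The entering group differs from both leaving groups in several ways at once, including one hydrogen-bond donor against none, so the compounds shown cannot tell which difference carries the step. They also leave open whether an amine or a carboxylic acid on the same aromatic ring would lower the value further.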